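This account rests on a few compounds, and the source may have more. Where it says the series, first, only, none or still open, it means among the compounds named here.

Ureido in place of amino on a shared pyrrole core? No: Carbamoyl on the amino nitrogen of compound 1

Measured compounds in a functional assay on HepG2 cells (Homo sapiens) for inhibition, read by sulforhodamine B assay, with a stated time of 24 h; on this read-out higher numbers stand for weaker inhibition and lower numbers for stronger inhibition:
compound 1, `N#Cc1c(-c2ccccc2)cn(-c2ccc(S(=O)(=O)Nc3ccccn3)cc2)c1N`, 5300 nM
compound 2, `O=c1[nH]cnc2c1c(-c1ccccc1)cn2-c1ccc(S(=O)(=O)Nc2ccccn2)cc1`, 4670 nM
compound 3, `Nc1ncnc2c1c(-c1ccccc1)cn2-c1ccc(S(=O)(=O)Nc2nccs2)cc1`, 4240 nM

Three compounds share a sulfonamide-bearing aryl group on the nitrogen of their core and a phenyl group on the adjacent ring carbon, but differ in the rest of the core and in the sulfonamide partner. Compound 1 carries a nitrile and an amino group on its core. In this assay compound 1 gives 5300 nM. Compound 2 gives 4670 nM, and compound 3 gives 4240 nM. The three numbers lie close together: the gaps from compound 1 to compound 2 and from compound 1 to compound 3 both fall within the usual scatter of repeated measurements, so no order among them can be read from these data.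

Compound 4, `N#Cc1c(-c2ccccc2)cn(-c2ccc(S(=O)(=O)Nc3ccccn3)cc2)c1NC(N)=O`, differs from compound 1 in one place: carbamoyl in place of hydrogen on a nitrogen on an aromatic ring. For the measured compounds named here, no measured pair in this set shows the effect of such a change, so the step is without precedent here. Given that the variations among compounds 1, 2 and 3 leave the numbers within the scatter, the step from compound 1 to compound 4 is expected to stay within the scatter as well, in no particular direction, as a 1.1-fold lower number from compound 1 to compound 4 (0.03 log units; within the scatter). For compound 4 the estimate is 5000 nM, with a range from 1500 nM to 16000 nM.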

Compound 4, half-maximal inhibitory concentration: 4120 nM
Compound 4: the middle estimate sits 1.2-fold (0.08 log units) above what was measured; the measured number falls inside the stated range.
By their numbers in this assay, from the lowest: compounds 4, 3, 2 and 1 (each within the scatter of the next).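

In this assay, for the compounds shown here, carbamoyl in place of hydrogen on a nitrogen on an aromatic ring gives a 1.3-fold lower number from compound 1 to compound 4 (0.11 log units; within the scatter) and so provides the first step in this set that differs in one place only. Compounds 1, 2 and 3 differ from one another in more than one place and could not isolate this nitrogen, whereas the amino to ureido change here shows that adding these 3 heavy atoms at this position produces no difference that can be separated from the scatter of repeated measurements. No measurement of any property of these compounds bears on this result, so the data offer no account of it. Going by these compounds, with one step at this position, the result cannot show whether other groups on this nitrogen would behave in the same way, and an acetyl group, a methyl group or a longer alkyl chain remains open there. On these data alone, it is also open whether the same change on a different core, or with a different partner on the sulfonamide, would give a similar result in this assay and whether a carboxylic acid in place of the nitrile would alter the picture.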